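Amide Nitrogen Swap in a Shared Core: Expected Solubility

The source may hold more compounds than are shown below. What is called first, only, known or untested is meant among the compounds shown, and "the series" means these compounds.

Compound 1 `Cn1ccc2ccc(-c3cc(Nc4ccccc4S(=O)(=O)NCC4CCOCC4)cc4nccnc34)cc21` and compound 2 `Cn1cc(NC(=O)c2ccncc2Nc2cc(-c3ccc4ccn(C)c4c3)c3nccnc3c2)cn1` were both tested in a physicochemical assay for solubility, read by spectrophotometry, measured as kinetic solubility, at pH 8, tested at 500 uM; on this read-out higher numbers stand for higher solubility and lower numbers for lower solubility. In this assay compound 1 gives 2 ug/mL. In this assay compound 2 gives 2 ug/mL, level with compound 1 within the scatter of the method. Compound 3 `CN1CCC(N(C)C(=O)c2ccncc2Nc2cc(-c3ccc4ccn(C)c4c3)c3nccnc3c2)C1` has not yet been measured. It differs from compound 2 in a single place: methyl(1-methylpyrrolidin-3-yl)amino in place of (1-methyl-1H-pyrazol-4-yl)amino on a carbonyl carbon. Among the measured compounds shown here, no measured pair shows this change, so its effect is not known from the data. Even so, compound 3 is expected to show a rise in solubility, with an estimated step of a 15-fold higher number from compound 2 to compound 3 (1.18 log units; beyond the scatter). The estimate for compound 3 in this assay is 30 ug/mL, in a range from 5 ug/mL to 150 ug/mL.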

Compound 3, solubility: 245 ug/mL
The estimate for compound 3 lay 8.2-fold (0.91 log units) below the measured number, outside the stated range (above it).
By their numbers in this assay, from the lowest: compounds 1 and 2 (each within the scatter of the next); then compound 3.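

The group on the carbonyl carbon turns out to matter greatly: methyl(1-methylpyrrolidin-3-yl)amino in place of (1-methyl-1H-pyrazol-4-yl)amino gives a 120-fold higher number from compound 2 to compound 3 (2.09 log units; beyond the scatter) in this assay on an otherwise unchanged molecule. This one change also replaces an aromatic ring with a non-aromatic one and removes the hydrogen-bond donor. Nothing measured here explains the rise. Which part of the entering group goes with the step stays open. Also open, as far as these compounds go, is how a morpholine or a plain dimethylamino group on the same carbonyl carbon would read.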